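Methylsulfonyl on the benzyl arm: an expected value for compound 4

The source may hold more compounds than are shown below. What is called first, only, known or untested is meant among the compounds shown, and "the series" means these compounds.

Measured compounds:
compound 1, `CN(C)CC[C@H](CSc1ccccc1)Nc1ccc(S(=O)(=O)NC(=O)c2ccc(N3CCC(=Cc4ccc(F)cc4)CC3)cc2)cc1[N+](=O)[O-]`, 600 nM
compound 2, `CN(C)CC[C@H](CSc1ccccc1)Nc1ccc(S(=O)(=O)NC(=O)c2ccc(N3CCC(=Cc4ccccc4C#N)CC3)cc2)cc1[N+](=O)[O-]`, 1600 nM
compound 3, `CN(C)CC[C@H](CSc1ccccc1)Nc1ccc(S(=O)(=O)NC(=O)c2ccc(N3CCN(Cc4ccccc4)CC3)cc2)cc1[N+](=O)[O-]`, 1700 nM

All three share the same core and were tested in a functional assay (FL5.12 cells, Mus musculus) with Apoptosis regulator Bcl-2 (Homo sapiens) as the target; a lower number here means that less compound is needed, a higher number that more compound is needed for the effect. Compound 3 has the highest number of the three in this assay; its value and that of compound 2 lie within the scatter of each other, while compound 1 sits clearly lower. Compound 4, `CN(C)CC[C@H](CSc1ccccc1)Nc1ccc(S(=O)(=O)NC(=O)c2ccc(N3CCN(Cc4ccccc4S(C)(=O)=O)CC3)cc2)cc1[N+](=O)[O-]`, is not yet measured. It differs from compound 3 by methylsulfonyl in place of hydrogen on an aromatic carbon.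

Among the compounds with values here, no measured pair changes a substituent on this benzyl ring, so there is no step that bears on it directly. The nearest comparison is the step of a 2.7-fold higher number from compound 1 to compound 2 (0.43 log units; beyond the scatter), where swapping one substituted phenyl for another on the terminal ring of the other piperidine series gave only a modest rise. On that basis one expects compound 4 to show at most a small step, if any, beyond the scatter, and the estimate for compound 4 in this assay is 2000 nM, within 800 nM to 5000 nM, corresponding to an expected step of a 1.2-fold higher number from compound 3 to compound 4 (0.07 log units; within the scatter).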

Compound 4, half-maximal effective concentration: 6800 nM
Compound 4: middle estimate off by 3.4-fold (0.53 log units), on the low side; measured number above the stated range.
By their numbers in this assay, from the lowest: compound 1; then compounds 2 and 3 (each within the scatter of the next); then compound 4.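

The benzyl arm proved sensitive to substitution: in this assay, methylsulfonyl on an aromatic carbon, ortho to a large group, gives a 4.0-fold higher number from compound 3 to compound 4 (0.60 log units; beyond the scatter) and so moves the value clearly upward. Within the data shown here, no earlier pair had changed this ring, so this is the first sign that the position does not accept every group without a cost, and here the added group raises the amount of compound needed rather than lowering it. No measurement at hand explains the rise.

A single substituent cannot show whether the rise belongs to methylsulfonyl itself or would follow any group at this place, such as a methyl, a fluorine or an amine. From the compounds shown here alone, it also remains open whether methylsulfonyl elsewhere on the benzyl ring would give a step of similar size.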